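The source may hold more compounds than are shown below. What is called first, only, known or untested is meant among the compounds shown, and "the series" means these compounds.

Measured compounds:
compound 1, `Cc1cccc(C)c1-c1cccc(COc2ccc3c(CC(=O)O)coc3c2)c1` — 4900 nM
compound 2, `Cc1cccc(C)c1-c1cccc(COc2ccc3c(c2)OCC3CC(=O)O)c1` — 27 nM
compound 3, `Cc1cccc(C)c1-c1cccc(COc2ccc3c(c2)CC3CC(=O)O)c1` — 69 nM

Compound 2 stands lowest of the three numbers in a functional assay on CHO cells for agonist activity at Free fatty acid receptor 1 (Homo sapiens), read by FLIPR, with a stated time of 90 s, in the presence of a further agent that is not named here; a higher number here means that more compound is needed for the effect, a lower number that less compound is needed. Its nearest neighbour is compound 3, whose value in this assay is 69 nM, a gap beyond the usual scatter, and the furthest is compound 1, whose value of 4900 nM lies far above it. The three share the same biaryl ether arm and differ only in the ring carrying the acetic acid.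

Compound 4, `O=C(O)CC1COc2cc(OCc3cccc(-c4ccc5sccc5c4)c3)ccc21`, keeps the core of compound 2 and alters the far end of the arm instead: 1-benzothiophen-5-yl in place of 2,6-dimethylphenyl on an aromatic carbon. Going by the values given here, no pair of measured compounds differing in exactly this way is available, so the size of the change can only be guessed. Since all three measured values carry the same 2,6-dimethylphenyl, nothing measured here shows how this assay responds to its replacement.

Compound 4 is expected to remain a reasonably potent agonist, with a modest loss relative to compound 2 judged likely, so the estimated step of a 3.7-fold higher number from compound 2 to compound 4 (0.57 log units; beyond the scatter) points toward a higher number. The estimate for compound 4 in this assay is 100 nM, with a range from 20 nM to 500 nM.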

Compound 4, half-maximal effective concentration: 180 nM
For compound 4 the middle estimate is 1.8-fold (0.26 log units) below the measured one, within the range that was stated.
By their numbers in this assay, from the lowest: compound 2; then compound 3; then compound 4; then compound 1.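

The three earlier compounds all carried 2,6-dimethylphenyl, so they could not show how this assay responds to a change at this end of the arm. Compound 4 now shows that the response is real but limited: placing 1-benzothiophen-5-yl on this aromatic carbon, meta to a large group, gives a 6.7-fold higher number from compound 2 to compound 4 (0.82 log units; beyond the scatter), so the two-ring group is accepted here at a modest cost. Nothing given here explains this step.

As far as these compounds go, it remains open how a plain phenyl or a 1-benzofuran-5-yl would stand at this position, and so which part of the change carries the step. Also open, from the compounds shown here alone, is whether 1-benzothiophen-5-yl would bring a step of similar size on the core of compound 3.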